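Cyano in place of methyl: expectations for compound 3

The compounds below may be only part of what the source reports. "The series", "measured", "known", "first", "only" and "open" are said of these compounds alone.

In a functional assay on SMMC-7721 cells (Homo sapiens) for cytotoxicity, read by MTT assay, with a stated time of 24 h (on this read-out lower numbers stand for stronger inhibition and higher numbers for weaker inhibition), compound 1 `Cc1ccc(S(=O)(=O)N2C/C(=C\c3ccncc3)C(=O)/C(=C/c3ccccc3F)C2)cc1` gives 13200 nM, while compound 2 `Cc1ccc(S(=O)(=O)N2C/C(=C\c3ccncc3)C(=O)/C(=C/c3ccccc3C(F)(F)F)C2)cc1` gives 5590 nM. Among the measured compounds shown here, compound 2 therefore holds the lower of the two numbers so far. For the measured compounds named here, the only measured step is a 2.4-fold lower number from compound 1 to compound 2 (0.37 log units; beyond the scatter), with trifluoromethyl in place of fluoro on an aromatic carbon. This step is modest but lies beyond the usual scatter.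

Compound 3 `N#Cc1ccc(S(=O)(=O)N2C/C(=C\c3ccncc3)C(=O)/C(=C/c3ccccc3C(F)(F)F)C2)cc1` keeps the trifluoromethyl group of compound 2 and changes one other place: cyano in place of methyl on an aromatic carbon. This puts cyano in place of methyl on an aromatic carbon, turning 4-methylphenyl into 4-cyanophenyl. Going by the values given here, the measured step lies elsewhere in the molecule, and no measured pair varies this group, so the data give no direct guide to the swap. Among the compounds with values here, the modest size of the one known step offers only a rough scale, and no clear direction can be drawn from it. A shift beyond the scatter is therefore not expected. The expected change is a 1.2-fold lower number from compound 2 to compound 3 (0.07 log units; within the scatter). In this assay, the estimate for compound 3 is 4800 nM, with an expected range of 1900 nM to 12000 nM.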

Compound 3, half-maximal inhibitory concentration: 9610 nM
The estimate for compound 3 lay 2.0-fold (0.30 log units) below the measured number; the range from low to high includes it.
By their numbers in this assay, from the lowest: compounds 2, 3 and 1 (each within the scatter of the next, the first and the last beyond it).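

In this assay, among the compounds shown here, the change from 4-methylphenyl to 4-cyanophenyl gives a 1.7-fold higher number from compound 2 to compound 3 (0.24 log units; within the scatter), the first reading of any change at this group. Unlike a 2.4-fold lower number from compound 1 to compound 2 (0.37 log units; beyond the scatter), which came from trifluoromethyl in place of fluoro, cyano in place of methyl on this aromatic carbon, para to a large group, leaves the two compounds inseparable within the usual scatter. No measurement shown here bears on the reason for this result.

The compounds shown leave open whether this position responds at all to a group further removed from methyl and cyano, such as an amine, a carboxylic acid or a longer chain, since this single swap is the only reading there. For the compounds shown here, they also leave open whether cyano in place of methyl would give a similar step with fluoro rather than trifluoromethyl on the other aromatic ring, as the swap is seen only with the trifluoromethyl group of compound 2 in place.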